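The compounds below may be only part of what the source reports. "The series", "measured", "known", "first", "only" and "open" are said of these compounds alone.

Compound 1 `O=C(CN(c1nc(Cl)nc2[nH]cnc12)C1CC1)N[C@@H](CO)C(=O)OCc1ccccc1`: 27.9%
Compound 2 `CC(C)[C@H](NC(=O)CN(c1nc(Cl)nc2[nH]cnc12)C1CC1)C(=O)OCc1ccccc1`: 17.9%
Compound 3 `O=C(CN(c1nc(Cl)nc2[nH]cnc12)C1CC1)N[C@@H](CC(=O)OCc1ccccc1)C(=O)OCc1ccccc1`: 6.68%

All three values come from a functional assay on the whole organism (Tail, strain ICR) with Mus musculus as the target, in the tail flick test, with a stated time of 150 min, at a dose of 25 umol/kg by the oral route; a higher number here means a stronger effect of the compound at the dose given, a lower number a weaker effect. Compound 3 holds the lowest number of the three: the step of a number 21.2 percentage points lower from compound 1 to compound 3 (beyond the scatter) and the step of a number 11.2 percentage points lower from compound 2 to compound 3 (beyond the scatter) both lie beyond the scatter. Compound 4 `NC(=O)CC[C@H](NC(=O)CN(c1nc(Cl)nc2[nH]cnc12)C1CC1)C(=O)OCc1ccccc1` has not yet been measured. It differs from compound 3 in one place: carbamoylmethyl in place of benzyloxycarbonyl on a saturated chain carbon, two bonds along the chain from an amide-type nitrogen and a carbonyl carbon. The measured step that bears on this is a number 21.2 percentage points lower from compound 1 to compound 3 (beyond the scatter), where the group now leaving had entered at the same place and went with a modest fall. Taking it away again in compound 4 is therefore expected to recover part of that loss, an estimated step of a number 11.3 percentage points higher from compound 3 to compound 4 (beyond the scatter) in this assay. Compound 4 is expected to give about 18%, within a range from 6% to 32%.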

Compound 4, a percentage reported as activity, at one dose (the size of the read-out at that dose, not a potency): 31.1%
For compound 4 the middle estimate is 13.1 percentage points below the measured one; the measured number falls inside the stated range.
By their numbers in this assay, from the lowest: compound 3; then compounds 2, 1 and 4 (each within the scatter of the next, the first and the last beyond it).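

In this assay, the fall linked to benzyloxycarbonyl at this place is more than partly reversible: carbamoylmethyl in its place gives a number 24.4 percentage points higher from compound 3 to compound 4 (beyond the scatter). The 2-carbamoylethyl chain also beats isopropyl, with a number 13.2 percentage points higher from compound 2 to compound 4 (beyond the scatter). Against hydroxy at this place, carbamoylmethyl gives a number 3.2 percentage points higher from compound 1 to compound 4 (within the scatter), so these two side chains cannot be told apart here, and a small side-chain end that carries a hydrogen-bond donor is seen with both.

From the compounds shown here alone, whether a carboxylic acid, an amine or a longer chain ending in the same amide would keep this level remains open. Nothing available explains the differences between these side chains.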